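Fluoro for Iodo: Expecting a Step Within the Scatter

The source may report more compounds than this note shows. Statements on the series, on what has been measured and on what is new or still open speak of the compounds shown alone.

Compound 1 `O=c1cc(-c2ccccc2)oc2cc(OCCCCNc3nc4ccc([N+](=O)[O-])cc4s3)cc(O)c12`: 8.14 ug/mL
Compound 2 `O=c1cc(-c2ccccc2)oc2cc(OCCCCNc3nc4ccc(I)cc4s3)cc(O)c12`: 9.84 ug/mL

In a physicochemical assay, read by spectrophotometry, with a stated time of 10 min (a higher number here means a weaker inhibitor, a lower number a stronger inhibitor), compound 1 gives 8.14 ug/mL and compound 2 gives 9.84 ug/mL. Going by the values given here, compound 2 holds the highest of the two numbers, yet its only neighbour is compound 1 and that gap, a 1.2-fold higher number from compound 1 to compound 2 (0.08 log units; within the scatter), lies within the scatter. Compound 3 `O=c1cc(-c2ccccc2)oc2cc(OCCCCNc3nc4ccc(F)cc4s3)cc(O)c12` is not yet measured; it differs from compound 2 by fluoro in place of iodo on an aromatic carbon. Among the compounds with values here, the one step that bears on this change, a 1.2-fold higher number from compound 1 to compound 2 (0.08 log units; within the scatter), also exchanged the group on that same aromatic carbon and stayed within the scatter, so no change beyond the scatter is expected: a 1.0-fold lower number from compound 2 to compound 3 (0.02 log units; within the scatter). Compound 3 is estimated at 9.5 ug/mL, between 5 ug/mL and 18 ug/mL.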

Compound 3, half-maximal inhibitory concentration: 5.25 ug/mL
For compound 3 the middle estimate is 1.8-fold (0.26 log units) above the measured one; the range from low to high includes it.
By their numbers in this assay, from the lowest: compounds 3, 1 and 2 (each within the scatter of the next).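

In this assay the step from iodo to fluoro (a 1.9-fold lower number from compound 2 to compound 3 (0.27 log units; within the scatter)) and the step from nitro to fluoro (a 1.6-fold lower number from compound 1 to compound 3 (0.19 log units; within the scatter)) both stay within the scatter. Three different groups on this one aromatic carbon therefore cannot be told apart in this test, so the earlier single step now holds for a third group. No measurement shown here accounts for the closeness of these numbers. On these data alone, whether an amine or a carboxylic acid on this carbon would also stay within the scatter remains open, as does the effect of a longer chain.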